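Replacing the 4-bromophenyl group of compound 2

This account rests on a few compounds, and the source may have more. Where it says the series, first, only, none or still open, it means among the compounds named here.

Measured in a functional assay on FM3A cells (Mus musculus) for antiproliferative activity, with a stated time of 48 h; a higher number here means a weaker inhibitor, a lower number a stronger inhibitor:
- compound 1 `C=C(Br)C(=O)Nc1ccc(/C=C/C(=O)c2ccccc2)cc1`: 3900 nM
- compound 2 `C=C(Br)C(=O)Nc1ccc(/C=C/C(=O)c2ccc(Br)cc2)cc1`: 1100 nM
- compound 3 `C=C(Br)C(=O)Nc1ccc(/C=C/C(=O)c2ccc(I)cc2)cc1`: 8300 nM

Among these three, compound 2 has the lowest number in this assay, at 1100 nM, and its steps to both others lie beyond the scatter. Compound 4 `C=C(Br)C(=O)Nc1ccc(/C=C/C(=O)c2cccc(OC)c2)cc1` has not yet been measured. It carries 3-methoxyphenyl in place of 4-bromophenyl on a carbonyl carbon.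

For the measured compounds named here, no measured compound carries a methoxy group, so the known steps bear on this change only indirectly. Bromo in place of hydrogen gave a 3.5-fold lower number from compound 1 to compound 2 (0.55 log units; beyond the scatter). Iodo in place of hydrogen gave a 2.1-fold higher number from compound 1 to compound 3 (0.33 log units; beyond the scatter), and iodo in place of bromo gave a 7.5-fold higher number from compound 2 to compound 3 (0.88 log units; beyond the scatter). All three steps are modest. Compound 2 sits at the low end of the set, while compound 1, without either halogen, stands at 3900 nM. A modest move toward a higher number is therefore expected, with an estimated step of a 2.9-fold higher number from compound 2 to compound 4 (0.46 log units; beyond the scatter). For compound 4 the estimated value is 3200 nM, with an expected range of 1100 nM to 9500 nM.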

Compound 4, half-maximal inhibitory concentration: 2700 nM
Beside the measured number, compound 4's estimate is 1.2-fold (0.07 log units) above it; low and high end bracket the measured number.
By their numbers in this assay, from the lowest: compound 2; then compounds 4 and 1 (each within the scatter of the next); then compound 3.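

In this assay, 3-methoxyphenyl in place of 4-bromophenyl on a carbonyl carbon gives a 2.5-fold higher number from compound 2 to compound 4 (0.39 log units; beyond the scatter), so the bromo compound keeps the lowest number of the four. Methoxy in place of hydrogen gives a 1.4-fold lower number from compound 1 to compound 4 (0.16 log units; within the scatter), so this group, unlike bromo and iodo, leaves the number within the scatter of the unsubstituted phenyl compound. 3-Methoxyphenyl in place of 4-iodophenyl gives a 3.1-fold lower number from compound 3 to compound 4 (0.49 log units; beyond the scatter), which shows that the high number of the iodo compound does not extend to this substituted ring.

Nothing available explains these differences. The compounds shown cannot separate the methoxy group from its place on the ring, and how a 4-methoxyphenyl, a 3-bromophenyl or an aminophenyl group would behave here remains open.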